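Swapping the aryl substituent on a shared core

A few compounds are considered here, and "the series" means these few. Any claim that something is new, unique, unknown or untested is made for them only; others in the source may bear on it.

Of the compounds shown here, two built on one core have been tested in a functional assay on the whole organism (strain Wistar) for inhibition, with Rattus norvegicus as the target, read by paw edema, with stated times of 30 min and 3 h, at a dose of 200 mg/kg by the oral route; on this read-out lower numbers stand for less inhibition and higher numbers for more inhibition at the one dose given (going by the name of the read-out). Compound 1 `COc1cccc(-c2cc3c(n2-c2ccc(O)c(C(=O)O)c2)CCCC3)c1` gives 20% in this assay. Compound 2 `COc1ccccc1-c1cc2c(n1-c1ccc(O)c(C(=O)O)c1)CCCC2` gives 50% and stands highest of the two numbers, with compound 1 as its nearest neighbour. Among the measured compounds shown here, the single measured step, a number 30 percentage points higher from compound 1 to compound 2 (beyond the scatter), accompanies 2-methoxyphenyl in place of 3-methoxyphenyl on an aromatic carbon.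

Compound 3 `Cc1ccc(-c2cc3c(n2-c2ccc(O)c(C(=O)O)c2)CCCC3)cc1` has not yet been measured. It differs from compound 2 in one place: 4-methylphenyl in place of 2-methoxyphenyl on an aromatic carbon. For the measured compounds named here, no measured step matches this change directly. Going by the values given here, the only step to hand, a number 30 percentage points higher from compound 1 to compound 2 (beyond the scatter), shows that relocating the methoxy group on the phenyl shifts the read-out by a modest amount beyond the scatter. Because compound 2 reached 50% with 2-methoxyphenyl while compound 1 with 3-methoxyphenyl stayed at 20%, a downward step is expected once 4-methylphenyl replaces 2-methoxyphenyl, estimated at a number 20 percentage points lower from compound 2 to compound 3 (beyond the scatter). Compound 3 is therefore expected to give 30% in this assay, within a range from 10% to 55%.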

Compound 3, a percentage reported as inhibition, in the whole organism at one dose (the size of the read-out at that dose, not a potency): 30%
Compound 3: the middle estimate sits on the measured number at the digits printed; the range from low to high includes it.
By their numbers in this assay, from the lowest: compounds 1 and 3 (each within the scatter of the next); then compound 2.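

In this assay, replacing 2-methoxyphenyl with 4-methylphenyl on the aromatic carbon next to the ring nitrogen gives a number 20 percentage points lower from compound 2 to compound 3 (beyond the scatter), which leaves compound 2 alone at the top of the three compounds. Replacing 3-methoxyphenyl with 4-methylphenyl at the same place gives a number 10 percentage points higher from compound 1 to compound 3 (within the scatter), so the presence of a methoxy group does not by itself go with the higher number: compound 1 carries one, yet it cannot be separated from compound 3, which carries a methyl group instead. No measurement at hand offers an explanation for how this position responds to these changes.

The step from compound 2 to compound 3 changes both the kind of substituent and its place on the phenyl ring, so the compounds shown cannot say which of the two goes with the lower number. They also leave open how this position would respond to an unsubstituted phenyl ring, or to a phenyl ring carrying an amine or a carboxylic acid, and each reading rests on a single dose.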